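Isopropyl to Hexyl: One Step Measured, One Awaited

The source may hold more compounds than are shown below. What is called first, only, known or untested is meant among the compounds shown, and "the series" means these compounds.

Compound 1, `Cc1ccc(S(=O)(=O)N2CC[C@@H](Br)C[C@@H]2CC(C)C)cc1`, gives 39000 nM in a functional assay on A2780 cells (Homo sapiens) for antiproliferative activity, read by sulforhodamine B assay, with a stated time of 48 h; on this read-out lower numbers stand for stronger inhibition of growth and higher numbers for weaker inhibition of growth.
Compound 2, `CCCCCCC[C@H]1C[C@H](Br)CCN1S(=O)(=O)c1ccc(C)cc1`, shows in this assay only a limit of the assay, not a number: > 100000 nM.
Compound 3, `Cc1ccc(S(=O)(=O)N2CCC(Cl)=CC2CC(C)C)cc1`, gives 35000 nM in this assay.

The change from compound 1 to compound 2 is hexyl in place of isopropyl on a saturated chain carbon bound to a saturated ring carbon. It brought an at least 2.5-fold higher number from compound 1 to compound 2 (0.40 log units; beyond the scatter), and since compound 2 sits at the limit of > 100000 nM in this assay, at which 1 of the 3 values shown sits, the true size of that step is not pinned down. Compound 3 has a different core; how its core differs from that of compound 1 is not broken down here. Its number and that of compound 1 lie within the usual scatter of each other, so neither can be called weaker or stronger in this assay.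

Compound 4, `CCCCCCCC1C=C(Cl)CCN1S(=O)(=O)c1ccc(C)cc1`, has not yet been measured. It differs from compound 3 by hexyl in place of isopropyl on a saturated chain carbon bound to a saturated ring carbon, the same change as from compound 1 to compound 2. For compound 4 a step of similar size is expected, a 2.9-fold higher number from compound 3 to compound 4 (0.46 log units; beyond the scatter), which rests on an at least 2.5-fold higher number from compound 1 to compound 2 (0.40 log units; beyond the scatter). Compound 4 is thus expected near 100000 nM, plausibly between 50000 nM and 300000 nM, and may again register only as a limit.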

Compound 4, concentration for 50% growth inhibition: 92000 nM
Compound 4: the middle estimate sits 1.1-fold (0.04 log units) above what was measured; the measured number falls inside the stated range.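

Putting hexyl in place of isopropyl on the core of compound 3 gave a 2.6-fold higher number from compound 3 to compound 4 (0.42 log units; beyond the scatter) and so meant weaker inhibition of growth in this assay on this core too. Set side by side, the two steps run in the same direction, so in these two pairs the change carried over from one core to the other: the same change on two cores in this assay, an at least 2.5-fold higher number (0.40 log units; beyond the scatter) from compound 1 to compound 2 and a 2.6-fold higher number (0.42 log units; beyond the scatter) from compound 3 to compound 4; the limit leaves it open whether they differ. Compound 2 gives only a limit of the assay, > 100000 nM and not a number, so the data do not show whether the change has the same size on both cores, and two cores say nothing about how it would behave on a third.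

The compounds shown leave open how the number moves with chain length between isopropyl and hexyl, for instance with a butyl chain. They also leave open how a chain ending in an amine or a carboxylic acid would read in this assay on either core.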